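Amide variation on the pyrrole of the shared core

The source may hold more compounds than are shown below. What is called first, only, known or untested is meant among the compounds shown, and "the series" means these compounds.

Compound 1 `COC(=O)c1cccn1-c1ccc(Nc2ncc(Cl)c(Nc3ccccc3NS(C)(=O)=O)n2)c(OC)c1`: 2510 nM
Compound 2 `COc1cc(-n2cccc2C(=O)N2CCCC2)ccc1Nc1ncc(Cl)c(Nc2ccccc2NS(C)(=O)=O)n1`: 4580 nM
Compound 3 `COc1cc(-n2cccc2C(=O)N(C)C)ccc1Nc1ncc(Cl)c(Nc2ccccc2NS(C)(=O)=O)n1`: a limit only, > 10000 nM

In a functional assay on A549 cells (Homo sapiens) for antiproliferative activity, read by MTT assay, with a stated time of 72 h (on this read-out higher numbers stand for weaker inhibition and lower numbers for stronger inhibition), compound 1 gives 2510 nM and compound 2 gives 4580 nM. For compound 3 this assay reports only a limit, > 10000 nM, so compound 3 stands at the weak end of the numbers shown (the limit of > 10000 nM in this assay, at which 1 of the 3 values shown sits). Compound 4 `COc1cc(-n2cccc2C(=O)N2CC(O)C2)ccc1Nc1ncc(Cl)c(Nc2ccccc2NS(C)(=O)=O)n1` differs from compound 3 by 3-hydroxyazetidin-1-yl in place of dimethylamino on a carbonyl carbon. For the measured compounds named here, the steps that bear on this change are an at least 2.1-fold higher number from compound 2 to compound 3 (0.33 log units; beyond the scatter) and an at least 3.9-fold higher number from compound 1 to compound 3 (0.60 log units; beyond the scatter), both ending at the limit, so their full size is open. Because the ring amide of compound 2 gave 4580 nM, the number for compound 4 is expected to move back toward a measurable value, a step of an at least 1.2-fold lower number from compound 3 to compound 4 (0.09 log units; that floor lies within the scatter) in this assay. Compound 4 is estimated at 8000 nM, range 3000 nM to 25000 nM.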

Compound 4, half-maximal inhibitory concentration: 2080 nM
The estimate for compound 4 lay 3.8-fold (0.59 log units) above the measured number; the measured number lies below the stated range.
By their numbers in this assay, from the lowest: compounds 4, 1 and 2 (each within the scatter of the next, the first and the last beyond it). At a limit, above all of these: compound 3.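

Going by these compounds, on the carbonyl carbon, 3-hydroxyazetidin-1-yl returns a measurable number in this assay, with an at least 4.8-fold lower number from compound 3 to compound 4 (0.68 log units; beyond the scatter), a step whose full size stays open: the limit of > 10000 nM in this assay, at which 1 of the 4 values shown sits. The ring amides also separate from each other, with 3-hydroxyazetidin-1-yl in place of pyrrolidin-1-yl giving a 2.2-fold lower number from compound 2 to compound 4 (0.34 log units; beyond the scatter). In place of methoxy, the same group gives a 1.2-fold lower number from compound 1 to compound 4 (0.08 log units; within the scatter).

Open, on these data alone, is whether the hydroxy group or the four-membered ring accounts for these steps; azetidin-1-yl without the hydroxy group would separate the two. An amine or a carboxylic acid on that ring would test what else the position accepts.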